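The source may report more compounds than this note shows. Statements on the series, on what has been measured and on what is new or still open speak of the compounds shown alone.

Of the compounds shown here, two have numbers so far in a functional assay on MCF7 cells (Homo sapiens) for antiproliferative activity, read by MTT assay, with a stated time of 48 h; a higher number here means a weaker inhibitor, a lower number a stronger inhibitor. Compound 1 `Cc1ccc(/C=C/C(=O)Nc2nnc(-c3ccc(C)cc3)s2)cc1` gives 0.61 ug/mL, and compound 2 `O=C(/C=C/c1ccc(F)cc1)Nc1nnc(-c2ccc(Br)cc2)s1` gives 1.49 ug/mL. Compound 2 therefore holds the higher of the two numbers, which makes it the weaker inhibitor of the pair, and its gap to compound 1 lies beyond the usual scatter. Compound 3 `Cc1ccc(-c2nnc(NC(=O)/C=C/c3ccc(F)cc3)s2)cc1` is compound 2 with methyl in place of bromo on an aromatic carbon. For the measured compounds named here, no measured pair shows this change alone, since compound 1 and compound 2 differ in more than one place. Still, compound 1 at 0.61 ug/mL also carries the 4-methylphenyl group, so a modest move towards a lower number is expected, perhaps not beyond the scatter. The expected change is estimated as a 1.5-fold lower number from compound 2 to compound 3 (0.17 log units; within the scatter). For compound 3 the expected value is 1 ug/mL, with an estimated range of 0.4 ug/mL to 2.5 ug/mL.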

Compound 3, half-maximal inhibitory concentration: 1.27 ug/mL
Compound 3: middle estimate off by 1.3-fold (0.10 log units), on the low side; measured number inside the range.
By their numbers in this assay, from the lowest: compound 1; then compounds 3 and 2 (each within the scatter of the next).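

In this assay, exchanging 4-bromophenyl for 4-methylphenyl, with the fluoro group kept in place, gives a 1.2-fold lower number from compound 2 to compound 3 (0.07 log units; within the scatter), so at this position these two groups cannot be told apart. The other change, fluoro in place of methyl on an aromatic carbon with 4-methylphenyl kept in place, gives a 2.1-fold higher number from compound 1 to compound 3 (0.32 log units; beyond the scatter); of the two places where compound 1 and compound 2 differ, only this one now shows a step beyond the scatter, though a modest one. Nothing measured here speaks to why either step has its size.

Going by these compounds, it remains open whether an amine or a carboxylic acid at the position held by bromo and methyl would shift the number. On these data alone, it is also open whether the step from methyl to fluoro would look the same with 4-bromophenyl in place.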